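Capping one hydroxy group on compound 1

This account rests on a few compounds, and the source may have more. Where it says the series, first, only, none or still open, it means among the compounds named here.

Within the data shown here, in a functional assay on MDA-MB-468 cells (Homo sapiens) for cytotoxicity, read by sulforhodamine B assay, with a stated time of 48 h (a higher number here means a weaker inhibitor of growth, a lower number a stronger inhibitor of growth), compound 1 (`COc1cc(C(=O)c2ccc(OC)c(O)c2OC)cc(OC)c1O`) gives 864 nM and holds the lower of the two numbers available so far. Compound 2 (`COc1cc(C(=O)c2ccc3c(c2)oc(=O)n3S(C)(=O)=O)cc(OC)c1OC`) gives 2820 nM in this assay and so stands higher by a gap beyond the usual scatter. The two compounds differ in more than one place, so this gap says nothing about any single change.

Compound 3 (`COc1ccc(C(=O)c2cc(OC)c(OC)c(OC)c2)c(OC)c1O`) has not yet been measured. It departs from compound 1 in one place, where a hydroxy becomes a methoxy (methyl in place of hydrogen on an oxygen on an aromatic ring), with methyl in place of hydrogen on an oxygen on an aromatic ring. Among the measured compounds shown here, no measured pair shows this change directly, so the expectation is an uncertain judgement and the range is kept wide. A step towards a lower number in this assay is expected, meaning stronger inhibition of growth, though a result within the scatter of compound 1 would not be surprising. The expected change is a 4.3-fold lower number from compound 1 to compound 3 (0.64 log units; beyond the scatter) on this estimate. For compound 3 the estimated value is 200 nM with an expected range from 30 nM to 1200 nM in this measurement.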

Compound 3, concentration for 50% growth inhibition: 249 nM
Estimate against measurement, compound 3: 1.2-fold (0.10 log units) below; measured number inside the range.
By their numbers in this assay, from the lowest: compound 3; then compound 1; then compound 2.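

With a single change in hand, the series now has its first direct comparison: in this assay, going from hydroxy to methoxy on this oxygen gives a 3.5-fold lower number from compound 1 to compound 3 (0.54 log units; beyond the scatter). The hydrogen on this oxygen is therefore not required for growth inhibition in this measurement, and a methyl in its place goes with a lower number by more than the usual scatter. No measurement available here accounts for this step, which stands as an observation only.

The compounds shown leave open whether a larger group on this oxygen, such as an ethoxy group, or an amine in place of the oxygen, would keep or extend this gain, since only the methyl is represented at this position. They also leave open what the hydroxy group that compound 3 still carries contributes, and whether capping it with a methyl would move the number in the same direction, since compound 2 differs from compound 3 in more than one place and cannot answer that.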